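The source may report more compounds than this note shows. Statements on the series, on what has been measured and on what is new or still open speak of the compounds shown alone.

Measured so far:
- compound 1, `CCN1CCc2c(sc(NC(=O)Nc3ccc(Cl)cc3)c2C(N)=O)C1`: 3120 nM
- compound 2, `CN1CCc2c(sc(NC(=O)Nc3ccc(Cl)cc3)c2C(N)=O)C1`: 4700 nM
- compound 3, `CC(C)(C)C[N+]1(C)CCc2c(sc(NC(=O)Nc3ccc(Cl)cc3)c2C(N)=O)C1`: 290 nM

All three were read in a functional assay (strain AB) with Danio rerio as the target, read by microscopy, with a stated time of 1 h; on this read-out lower numbers stand for an effect already at smaller amounts and higher numbers for an effect only at larger amounts of compound. Compound 1 and compound 2 share one core and differ only in the group on the ring nitrogen; the change is hydrogen in place of methyl on a saturated chain carbon bound to an amine nitrogen in a ring and it gave a 1.5-fold higher number from compound 1 to compound 2 (0.18 log units; within the scatter). Compound 3 carries a differently substituted ring nitrogen; how its core differs from that of compound 1 is not broken down here. Against compound 1 and compound 2 the number for compound 3 is lower by steps that lie beyond the scatter.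

Compound 4, `CC(C)C[N+]1(C)CCc2c(sc(NC(=O)Nc3ccc(Cl)cc3)c2C(N)=O)C1`, is not yet measured. Its difference from compound 3 is hydrogen in place of methyl on a saturated chain carbon bound to three saturated chain carbons. This is the same kind of change as that from compound 1 to compound 2, though not the same: there the place was a saturated chain carbon bound to an amine nitrogen in a ring, here it is a saturated chain carbon bound to three saturated chain carbons. Because a 1.5-fold higher number from compound 1 to compound 2 (0.18 log units; within the scatter) stayed within the scatter, a similarly small step is expected, a 1.6-fold higher number from compound 3 to compound 4 (0.19 log units; within the scatter). For compound 4 the estimate in this assay is 450 nM, expected between 180 nM and 1200 nM.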

Compound 4, half-maximal effective concentration: 380 nM
Estimate against measurement, compound 4: 1.2-fold (0.07 log units) above; measured number inside the range.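

In this assay, hydrogen in place of methyl on a saturated chain carbon bound to three saturated chain carbons (tert-butyl to isopropyl, neopentyl to isobutyl) gives a 1.3-fold higher number from compound 3 to compound 4 (0.12 log units; within the scatter). Set beside the earlier step, the swap reads alike on both cores: the same change on two cores in this assay, a 1.5-fold higher number (0.18 log units; within the scatter) from compound 1 to compound 2 and a 1.3-fold higher number (0.12 log units; within the scatter) from compound 3 to compound 4, 1.1-fold (0.06 log units) apart, within the scatter of two such steps This rests on one pair per core, with the swap at a different place in each, so it shows only that neither of these two pairs separates beyond the scatter; it does not show that the swap would stay as quiet at another place or on a further core.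

The compounds shown leave open whether a longer chain on the ring nitrogen, such as n-hexyl, or a benzyl group there would read differently in this assay. Also open, on these data alone, is whether a chain ending in an amine or a carboxylic acid would hold the number of compound 3.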